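This account rests on a few compounds, and the source may have more. Where it says the series, first, only, none or still open, it means among the compounds named here.

Compound 3 `O=C(Nc1ccc(Cl)cc1)c1cccc(/C=C2\CC(=O)N(c3ccccc3)C2=O)c1` is one of three measured members of a shared core. In an ADME assay on SW480 cells (Homo sapiens) for cytotoxicity, read by MTT assay, with a stated time of 72 h (on this read-out higher numbers stand for weaker inhibition and lower numbers for stronger inhibition), compound 3 gives > 100000 nM, which is a limit of the assay rather than a number. Compound 1 `Cc1ccc(NC(=O)c2cccc(/C=C3\CC(=O)N(c4ccccc4)C3=O)c2)cc1C` gives > 100000 nM in this assay, also a limit. Compound 2 `O=C(Nc1ccc(OC(F)F)cc1)c1cccc(/C=C2\CC(=O)N(c3ccccc3)C2=O)c1` gives > 100000 nM in this assay, again a limit. The three steps among them are a step that the two limits leave unreadable from compound 1 to compound 2, a step that the two limits leave unreadable from compound 1 to compound 3 and a step that the two limits leave unreadable from compound 2 to compound 3; their sizes cannot be read because of the limit of > 100000 nM in this assay, at which 3 of the 3 values shown sit.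

Compound 4 `CCOc1ccc(NC(=O)c2cccc(/C=C3\CC(=O)N(c4ccccc4)C3=O)c2)cc1` differs from compound 3 by ethoxy in place of chloro on an aromatic carbon. Among the measured compounds shown here, none of the measured steps is readable, so no direction of change can be drawn from them; what they show is only that every variation of the amide-type nitrogen substituent so far has left the compound at the limit. Compound 4 is therefore expected to remain at or near that limit, with an estimated value of 150000 nM in a range from 50000 nM to 600000 nM. The step expected in this assay is a step that the limit leaves unreadable from compound 3 to compound 4, which means no change beyond the scatter.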

Compound 4, half-maximal inhibitory concentration: 91500 nM
Compound 4: middle estimate off by 1.6-fold (0.21 log units), on the high side, and the stated range covers the measured number.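

In this assay, compound 4 gives 91500 nM, the only number among the compounds shown that is not a limit, so a substituent on this aromatic carbon, para to a large group, can leave the compound within the measurable range. Ethoxy in place of chloro reads as an at least 1.0-fold lower number from compound 3 to compound 4 (0.03 log units; that floor lies within the scatter), and the two other comparisons read as an at least 1.0-fold lower number from compound 2 to compound 4 (0.03 log units; that floor lies within the scatter) and an at least 1.0-fold lower number from compound 1 to compound 4 (0.03 log units; that floor lies within the scatter). Each of these is only a floor, so none of them sets the 4-ethoxyphenyl group apart from the other three substituents beyond the scatter.

From the compounds shown here alone, how far the other three compounds really lie from compound 4 stays open, as their values are not numbers: the limit of > 100000 nM in this assay, at which 3 of the 4 values shown sit. Also open is whether a longer alkoxy chain such as propoxy, an amine or a carboxylic acid at this position would give a clearly lower number.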